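The source may hold more compounds than are shown below. What is called first, only, known or untested is meant among the compounds shown, and "the series" means these compounds.

Working notes on the series. Compound 1 `NC(=O)c1c(NC(=O)c2ccccc2I)sc2c1CCN(C(=S)Nc1ccccc1Cl)C2` carries iodo on an aromatic carbon of the benzamide part of the shared core. In a functional assay on HeLa cells (Homo sapiens) for antiproliferative activity, with a stated time of 24 h (on this read-out lower numbers stand for stronger inhibition and higher numbers for weaker inhibition), compound 1 gives only a limit, > 50000 nM. Compound 2 `COc1ccccc1C(=O)Nc1sc2c(c1C(N)=O)CCN(C(=S)Nc1ccccc1Cl)C2` has methoxy in place of that iodo. In this assay compound 2 likewise gives only a limit, > 50000 nM. The step that the two limits leave unreadable from compound 1 to compound 2 has no readable size; both ends sit at the same limit (the limit of > 50000 nM in this assay, at which 2 of the 2 values shown sit). Compound 2 therefore stands at the limit of this assay, with no number that sets it apart from compound 1.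

Compound 3 `CSc1ccccc1C(=O)Nc1sc2c(c1C(N)=O)CCN(C(=S)Nc1ccccc1Cl)C2` differs from compound 2 by methylsulfanyl in place of methoxy on an aromatic carbon. The one measured step, iodo to methoxy on the same aromatic carbon, is the only change of this kind in the series, and it gave no readable size. Nothing in the measured pair points to compound 3 leaving the limit. The step that the limit leaves unreadable from compound 2 to compound 3 is expected to stay within the scatter. Compound 3 is expected at 70000 nM in this assay, between 20000 nM and 250000 nM, most probably reported again only as a limit.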

Compound 3, half-maximal inhibitory concentration: 34700 nM
Estimate against measurement, compound 3: 2.0-fold (0.30 log units) above; the range from low to high includes it.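

In this assay, going by these compounds alone, compound 3 is the first compound of the series to give a number rather than a limit, which shows that this aromatic carbon, ortho to a large group, can carry a group that brings a compound of the series within the readable range. Methylsulfanyl in place of methoxy gives an at least 1.4-fold lower number from compound 2 to compound 3 (0.15 log units; that floor lies within the scatter), and methylsulfanyl in place of iodo gives an at least 1.4-fold lower number from compound 1 to compound 3 (0.15 log units; that floor lies within the scatter). Neither floor goes beyond the scatter, so a real difference is not established, and the full size of either step cannot be read since compound 1 and compound 2 give only limits: the limit of > 50000 nM in this assay, at which 2 of the 3 values shown sit.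

The step between compound 1 and compound 2 remains unreadable, and a single readable value cannot show whether the sulfur of methylsulfanyl matters or whether any group other than methoxy and iodo would give a number too. Open as well is how this aromatic carbon responds to groups such as an amine, a carboxylic acid or a longer chain such as ethylsulfanyl.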